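Methylsulfanyl in place of carbamoyl on the hydroxamate series

The compounds below may be only part of what the source reports. "The series", "measured", "known", "first", "only" and "open" are said of these compounds alone.

Within the data shown here, compound 2 `NC(=O)C[C@H](NC(=O)c1ccc(C#Cc2ccccc2)cc1)C(=O)NO` is the lower of the two measured members in a physicochemical assay for lipophilicity; a higher number here means a more lipophilic compound, a lower number a more polar compound: compound 2 gives 1, while compound 1 `C#CCNC(=O)C[C@H](NC(=O)c1ccc(C#Cc2ccccc2)cc1)C(=O)NO` gives 3. The one step shown, a number 2.00 log units lower from compound 1 to compound 2 (beyond the scatter), concerns the propargyl on the amide-type nitrogen and not the change considered here, but it shows that a single substitution on the side chain of this core can shift this assay by a large amount.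

Compound 3 `CSC[C@H](NC(=O)c1ccc(C#Cc2ccccc2)cc1)C(=O)NO` is not yet measured. It differs from compound 2 as follows: methylsulfanyl in place of carbamoyl on a saturated chain carbon, two bonds along the chain from an amide-type nitrogen and a carbonyl carbon. Among the measured compounds shown here, no measured pair shows this exchange, so the direction rests on the counted difference: one hydrogen-bond donor and one double bond outside aromatic rings leave, a sulfur enters. An increase in this assay beyond the scatter is expected, of a size comparable to, though probably somewhat smaller than, the step from compound 1 to compound 2. Compound 3 is therefore estimated at 2.7, with a range from 2.1 to 3.3, an expected step of a number 1.70 log units higher from compound 2 to compound 3 (beyond the scatter).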

Compound 3, distribution coefficient: 3
For compound 3 the middle estimate is 0.30 log units below the measured one; the range from low to high includes it.
By their numbers in this assay, from the lowest: compound 2; then compounds 1 and 3 (each within the scatter of the next).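

At this position, on a saturated chain carbon, two bonds along the chain from an amide-type nitrogen and a carbonyl carbon, methylsulfanyl in place of carbamoyl gives a number 2.00 log units higher from compound 2 to compound 3 (beyond the scatter) in this assay and is a large step. The exchange now has a measured pair of its own, and it shows that a large step on this side chain is not confined to the propargyl on the amide-type nitrogen. Methylsulfanyl in place of propargylcarbamoyl at the same place gives no change at the digits printed from compound 1 to compound 3 (within the scatter) in this assay, so two quite different side chains stand level here, with compound 2 apart from both; nothing accompanying these numbers accounts for the steps.

The compounds shown leave open whether the reading of compound 3 goes with the sulfur itself or simply with the removal of carbamoyl, and methoxy at this place would separate the two. Also open, on these data alone, is how far this assay moves with a longer chain such as ethylsulfanyl, or with an amine or a carboxylic acid on the same saturated chain carbon.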